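The compounds below may be only part of what the source reports. "The series", "measured", "known", "first", "only" and "open" are said of these compounds alone.

Compound 1 (`CC(=O)SCCC(CCCCC(=O)O)SC(C)=O`) gives "not active" (no number reported)
Compound 2 (`CC(=O)SCCC(CCCCC(=O)Nc1ccccc1)SC(C)=O`) gives 22.3%
Compound 3 (`CC(=O)SCCC(CCCCC(=O)Nc1ccccc1Cl)SC(C)=O`) gives "not active" (no number reported)

These readings come from a functional assay on HO8910 cells (Homo sapiens) for inhibition, read by MTT assay, with a stated time of 24 h, tested at 100 ug/mL; a higher number here means more inhibition of growth at the concentration tested, a lower number less inhibition of growth. Only compound 2 has a number here. Compound 3 stands without one and, like compound 1 , is reported as not active, so the distance between compound 3 and compound 2 cannot be given as a figure.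

The next compound to be tested is compound 4 (`CC(=O)SCCC(CCCCC(=O)Nc1cccc(Cl)c1)SC(C)=O`), which has the same atoms as compound 3 joined differently: 3-chlorophenyl in place of 2-chlorophenyl on an amide-type nitrogen. In words, 3-chlorophenyl takes the place of 2-chlorophenyl on an amide-type nitrogen, and the rest of the molecule stays the same.

Among the compounds with values here, no measured step shows what this kind of change does, so any forecast is tentative. A modest upward step from compound 3 is expected, small enough that compound 4 would remain within reach of a not-active report. This expectation rests on compound 2 , which reaches 22.3% in this assay and marks the only measured level of inhibition in the set. Compound 4 is not expected to clearly exceed that level.

For compound 4 the estimated inhibition is 15%, with an expected range from 0% to 35%.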

Compound 4, percent growth inhibition at one concentration: 38.2%
Beside the measured number, compound 4's estimate is 23.2 percentage points below it; the measured number lies above the stated range.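

In this assay, compound 3, with 2-chlorophenyl on the amide-type nitrogen, is reported as not active, whereas compound 4, with 3-chlorophenyl at the same place, gives 38.2%, so among these compounds the placement of the chlorine on the ring, and not only its presence, separates a numbered reading from a not-active report. The chloro group in place of hydrogen on an aromatic carbon also gives a number 15.9 percentage points higher from compound 2 to compound 4 (beyond the scatter), which shows that adding chlorine to the phenyl compound can go with more inhibition of growth, although compound 3 goes against any general rule of that kind. No measurement of any property of these groups is available to account for the difference between the two placements.

Going by these compounds, whether 4-chlorophenyl on the same nitrogen would read like compound 3 or like compound 4 remains open. On these data alone, it is also open whether a methoxy or trifluoromethyl group in the place of the chlorine would keep the reading that compound 4 gives.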